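Notes on the nitrile-bearing series in a paw edema model

The source may report more compounds than this note shows. Statements on the series, on what has been measured and on what is new or still open speak of the compounds shown alone.

Measured compounds:
compound 1 `N#Cc1c(-c2ccc(Cl)cc2)nc(SCC(=O)Nn2c(COc3ccc(Cl)cc3Cl)nc3ccccc3c2=O)[nH]c1=O` gives 61.5%
compound 2 `N#Cc1c(-c2ccccc2)nc(SCC(=O)Nn2c(COc3ccc(Cl)cc3Cl)nc3ccccc3c2=O)n(Cc2ccccc2)c1=O` gives 76%
compound 3 `Cn1c(SCC(=O)Nn2c(COc3ccc(Cl)cc3Cl)nc3ccccc3c2=O)nc(-c2ccc(Cl)cc2)c(C#N)c1=O` gives 80.8%

In a functional assay on the whole organism (strain albino) for inhibition, with Rattus norvegicus as the target, read by paw edema, with stated times of 1 h and 0.5 h, at a dose of 100 mg/kg by the oral route (a higher number here means more inhibition at the dose given (going by the name of the read-out), a lower number less inhibition), compound 3 gives the highest of the three numbers. Compound 2 lies within the usual scatter of compound 3, so no order between those two can be claimed; compound 1 lies furthest from compound 3, and that gap is beyond the scatter.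

Within the data shown here, the one step that changes a single place is a number 19.3 percentage points higher from compound 1 to compound 3 (beyond the scatter), which is a modest gain on substitution of the aromatic nitrogen.

Compound 4 `N#Cc1c(-c2ccc(Cl)cc2)nc(SCC(=O)Nn2c(COc3ccc(Cl)cc3Cl)nc3ccccc3c2=O)n(Cc2ccccc2)c1=O` differs from compound 3 by phenyl in place of hydrogen on a saturated chain carbon bound to an aromatic nitrogen. This is again a change on the group carried by the aromatic nitrogen, so the step from compound 1 to compound 3 bears on it, though it does not tell whether going further than methyl adds anything. Compound 2 carries the same benzyl on the aromatic nitrogen but lacks the chloro on the phenyl ring of the core, and its value sits within the scatter of compound 3. Among the measured compounds shown here, no step between compound 2 and compound 4 is known.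

Taking these together, the expectation for compound 4 in this assay is a step of about a number 2.8 percentage points lower from compound 3 to compound 4 (within the scatter), that is, none beyond the scatter. Compound 4 is therefore estimated at 78%, with a range from 64% to 90%.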

Compound 4, a percentage reported as inhibition, in the whole organism at one dose (the size of the read-out at that dose, not a potency): 61.5%
Compound 4: the middle estimate sits 16.5 percentage points above what was measured; the measured number lies below the stated range.
By their numbers in this assay, from the lowest: compounds 1 and 4 (each within the scatter of the next); then compounds 2 and 3 (each within the scatter of the next).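

At this position the size of the group matters: in this assay, replacing methyl with benzyl on the aromatic nitrogen gives a number 19.3 percentage points lower from compound 3 to compound 4 (beyond the scatter), so the gain seen for methyl does not extend to benzyl. Against hydrogen on that nitrogen, benzyl gives no change at the digits printed from compound 1 to compound 4 (within the scatter), which leaves methyl as the only one of these three groups with a step beyond the scatter when the phenyl ring of the core carries chloro. Among these compounds, the chloro itself also proves to matter with benzyl on the nitrogen, where chloro in place of hydrogen on an aromatic carbon gives a number 14.5 percentage points lower from compound 2 to compound 4 (beyond the scatter), a drop that the earlier compounds could not show. No measurement shown here accounts for either step.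

On these data alone, whether ethyl or a longer chain on the aromatic nitrogen stays with methyl or falls to the level of benzyl remains open, as does the effect of an amine carried at the end of such a chain. Also open, as far as these compounds go, is whether chloro on the aromatic carbon gives a similar step with hydrogen or methyl on the nitrogen, since the step is known only with benzyl there.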